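A few compounds are considered here, and "the series" means these few. Any claim that something is new, unique, unknown or untested is made for them only; others in the source may bear on it.

Measured so far in a physicochemical assay for metabolic stability, read by LC-MS, in phosphate buffer, with a stated time of 3 h, at pH 7.4, tested at 50 uM; on this read-out higher numbers stand for a more stable compound and lower numbers for a less stable compound:
- Compound 1 `C[C@@H](O)[C@H]1C(=O)N2C(C(=O)OCOC(=O)C(C)(C)C)=C(S[C@@H]3CN[C@H](C(=O)Nc4cccc(C(=O)O)c4)C3)[C@H](C)[C@H]12` gives > 95%, which is a limit of the assay.
- Compound 2 `CCOC(=O)C1=C(S[C@@H]2CN[C@H](C(=O)Nc3cccc(C(=O)OCC)c3)C2)[C@H](C)[C@@H]2[C@@H]([C@@H](C)OC(C)=O)C(=O)N12` gives > 95%, again a limit.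
- Compound 3 `C[C@@H](O)[C@H]1C(=O)N2C(C(=O)OCOC(=O)C(C)(C)C)=C(S[C@@H]3CN[C@H](C(=O)Nc4cccc(C(=O)OCOC(=O)C(C)(C)C)c4)C3)[C@H](C)[C@H]12` gives > 95%, also a limit.

Compound 1 therefore stands only at a limit, not at a number, and the same holds for the other two compounds, since (the limit of > 95% in this assay, at which 3 of the 3 values shown sit). Within the data shown here, the one measured step that bears on the change, a step that the two limits leave unreadable from compound 1 to compound 3, cannot be read for the same reason.

Compound 4 `C[C@@H](O)[C@H]1C(=O)N2C(C(=O)OCOC(=O)OC(C)(C)C)=C(S[C@@H]3CN[C@H](C(=O)Nc4cccc(C(=O)O)c4)C3)[C@H](C)[C@H]12` differs from compound 1 in one place: tert-butoxy in place of tert-butyl on a carbonyl carbon. With every measured value at the limit, no step beyond the scatter is expected in this assay; the step that the limit leaves unreadable from compound 1 to compound 4 is estimated to stay within it. Compound 4 is thus expected to give 96%, in the range 88% to 100%.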

Compound 4, percent of the compound remaining: > 95%
Compound 4: only a limit was reported; the forecaster's own chance of this, stated with the estimate: 80%; the middle value does not contradict the limit.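

Compound 1 and compound 4 both sit at a limit of the assay, so no step can be read between them: the limit of > 95% in this assay, at which 4 of the 4 values shown sit.

Whether any change in one place moves a compound in this assay stays open for the compounds shown.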